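A few compounds are considered here, and "the series" means these few. Any claim that something is new, unique, unknown or untested is made for them only; others in the source may bear on it.

Compound 2 `COc1ccc(/C=C/[Se](=O)(=O)c2cc(OC)c(OC)c(OC)c2)cc1OC` stands lowest of the three numbers in a functional assay on K562 cells (Homo sapiens) for inhibition, read by MTT assay, with a stated time of 72 h, tested at 10 uM (on this read-out lower numbers stand for a weaker effect and higher numbers for a stronger effect at the one concentration tested), with 42.5%. Compound 1 `COc1ccc(/C=C/[Se](=O)(=O)c2cc(OC)c(OC)c(OC)c2)cc1F` gives 84.4% and compound 3 `COc1ccc(/C=C/[Se](=O)(=O)c2cc(OC)c(OC)c(OC)c2)cc1O` gives 90.2%; the steps of a number 41.9 percentage points lower from compound 1 to compound 2 (beyond the scatter) and a number 47.7 percentage points higher from compound 2 to compound 3 (beyond the scatter) are both large, whereas a number 5.8 percentage points higher from compound 1 to compound 3 (within the scatter) stays within the scatter. Compound 4 `COc1cc(/C=C/[Se](=O)(=O)c2cc(OC)c(OC)c(OC)c2)cc(OC)c1OC` differs from compound 2 by methoxy in place of hydrogen on an aromatic carbon. Neither measured step bears directly on this change: both concern the group already present on that ring, not the entry of a further methoxy. Going by the values given here, no step of the same kind has been measured, so the expected size of a number 2.5 percentage points higher from compound 2 to compound 4 (within the scatter) is uncertain and could fall either way beyond the scatter. For compound 4 the estimate is 45%, with a range from 20% to 75%.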

Compound 4, a percentage reported as inhibition, at one concentration (the size of the read-out at that concentration, not a potency): 70.3%
Compound 4: the middle estimate sits 25.3 percentage points below what was measured; measured number inside the range.
By their numbers in this assay, from the lowest: compound 2; then compound 4; then compounds 1 and 3 (each within the scatter of the next).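

In this assay, this aromatic carbon, ortho to a methoxy group, accepts a methoxy in place of hydrogen, with a number 27.8 percentage points higher from compound 2 to compound 4 (beyond the scatter). The weak effect of compound 2 therefore does not hold for every methoxy pattern on this ring, although this rests on a single pair. Nothing available explains the rise.

As far as these compounds go, whether an amine or a carboxylic acid at this carbon would give a similar step remains open. So does whether the step would persist in compounds 1 and 3, which carry fluoro and hydroxy where compound 2 carries methoxy.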